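Amide variation on the anilinopyrimidine acrylamide series

This account rests on a few compounds, and the source may have more. Where it says the series, first, only, none or still open, it means among the compounds named here.

Measured so far:
- compound 1 `C=CC(=O)Nc1ccc(-c2nc(Cl)cc(Nc3ccc(C(=O)N(CC)CC)cc3)n2)cc1`: 12500 nM
- compound 2 `C=CC(=O)Nc1ccc(-c2nc(Cl)cc(Nc3ccc(C(=O)N4CCCC4)cc3)n2)cc1`: 19200 nM

In a functional assay on Raji cells (Homo sapiens) for antiproliferative activity, read by MTT assay, with a stated time of 48 h (on this read-out higher numbers stand for weaker inhibition and lower numbers for stronger inhibition), compound 1 gives 12500 nM, the lower of the two numbers recorded, with compound 2 nearest at 19200 nM. Within the data shown here, the single measured step, a 1.5-fold higher number from compound 1 to compound 2 (0.19 log units; within the scatter), exchanges one tertiary amide for another and changes nothing beyond the scatter.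

Compound 3 `C=CC(=O)Nc1ccc(-c2nc(Cl)cc(Nc3ccc(C(=O)Nc4cc(C)ccc4C)cc3)n2)cc1` is not yet measured. It differs from compound 1 in that ((2,5-dimethylphenyl)amino in place of diethylamino on a carbonyl carbon). Among the measured compounds shown here, no measured step covers a move from a tertiary amide to a secondary anilide, so the pyrrolidine step gives only indirect guidance: amide variation at this position has so far left this assay essentially unchanged. On that basis no step beyond the scatter is expected for compound 3, and the estimated change is a 1.3-fold lower number from compound 1 to compound 3 (0.10 log units; within the scatter). Compound 3 is therefore expected to give about 10000 nM, within a range of 2500 nM to 40000 nM.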

Compound 3, half-maximal inhibitory concentration: 20900 nM
For compound 3 the middle estimate is 2.1-fold (0.32 log units) below the measured one, and the stated range covers the measured number.
By their numbers in this assay, from the lowest: compounds 1, 2 and 3 (each within the scatter of the next).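

In this assay, the secondary anilide with (2,5-dimethylphenyl)amino on the carbonyl carbon stays within the scatter of both tertiary amides (a 1.7-fold higher number from compound 1 to compound 3 (0.22 log units; within the scatter); a 1.1-fold higher number from compound 2 to compound 3 (0.04 log units; within the scatter)). The pyrrolidin-1-yl step only exchanged one tertiary amide for another, whereas this change brings in a six-membered aromatic ring and a hydrogen-bond donor, and still no step beyond the scatter appears at this position. No available evidence bears on this result.

The compounds shown leave open whether any group here can produce a step beyond the scatter, for example a basic amine such as piperazin-1-yl or a carboxylic acid carried on the anilide ring. They also leave open how the plain phenylamino group, lacking both methyl groups, compares with (2,5-dimethylphenyl)amino.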